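The source may hold more compounds than are shown below. What is called first, only, known or untested is meant among the compounds shown, and "the series" means these compounds.

Measured compounds in an assay on HeLa cells for inhibition of Indoleamine 2,3-dioxygenase 1 (Homo sapiens), read by spectrophotometry, with a stated time of 24 h; on this read-out higher numbers stand for an effect only at larger amounts of compound and lower numbers for an effect already at smaller amounts:
compound 1 `NS(=O)(=O)CCNc1nonc1/C(=N/O)Nc1ccc(F)c(Br)c1` gives 11 nM
compound 2 `O=S(=O)(CCNc1nonc1/C(=N/O)Nc1ccc(F)c(Br)c1)N1CCC1` gives 143 nM
compound 3 `C#CCNS(=O)(=O)CCNc1nonc1/C(=N/O)Nc1ccc(F)c(Br)c1` gives 33 nM

Compound 3 holds the second highest of the three numbers. Its nearest neighbour is compound 1, as the step of a 3.0-fold higher number from compound 1 to compound 3 (0.48 log units; beyond the scatter) shows; its furthest is compound 2, as the step of a 4.3-fold lower number from compound 2 to compound 3 (0.64 log units; beyond the scatter) shows. The largest step in the set is a 13-fold higher number from compound 1 to compound 2 (1.11 log units; beyond the scatter).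

Compound 4 `O=S(=O)(CCNc1nonc1/C(=N/O)Nc1ccc(F)c(Br)c1)NCC1CC1` differs from compound 3 only in that (cyclopropyl in place of ethynyl on a saturated chain carbon bound to a sulfonamide nitrogen). Going by the values given here, no measured pair makes exactly this exchange. Among the compounds with values here, the steps that bear on it are a 3.0-fold higher number from compound 1 to compound 3 (0.48 log units; beyond the scatter), which shows that a propargyl group on the sulfonamide nitrogen costs a modest amount against the unsubstituted sulfonamide, and a 4.3-fold lower number from compound 2 to compound 3 (0.64 log units; beyond the scatter), which shows that the open propargylamino substituent on the sulfonyl sulfur reads clearly better than azetidin-1-yl. Both point to the substituent on the sulfonamide nitrogen mattering, but neither tells how ethynyl and cyclopropyl compare on that chain carbon, so the direction is uncertain and the size is expected to be small, within or just beyond the scatter, with a slightly higher number somewhat more likely: a 1.4-fold higher number from compound 3 to compound 4 (0.13 log units; within the scatter) is the expected step. For compound 4 the estimate is 45 nM, with a range from 15 nM to 130 nM.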

Compound 4, half-maximal effective concentration: 268 nM
Compound 4: the middle estimate sits 6.0-fold (0.77 log units) below what was measured; measured number outside the range, above it.
By their numbers in this assay, from the lowest: compound 1; then compound 3; then compounds 2 and 4 (each within the scatter of the next).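

In this assay, the chain carbon bound to the sulfonamide nitrogen proves sensitive to what it carries: cyclopropyl in place of ethynyl gives an 8.1-fold higher number from compound 3 to compound 4 (0.91 log units; beyond the scatter), so propargyl and cyclopropylmethyl are not interchangeable here. Measured against the unsubstituted sulfonamide, cyclopropylmethyl gives a 24-fold higher number from compound 1 to compound 4 (1.39 log units; beyond the scatter), while propargyl gives only a 3.0-fold higher number from compound 1 to compound 3 (0.48 log units; beyond the scatter), so the cost of substituting this nitrogen depends strongly on the substituent. The step of a 1.9-fold higher number from compound 2 to compound 4 (0.27 log units; within the scatter) places (cyclopropylmethyl)amino level with azetidin-1-yl on the sulfonyl sulfur, which shows that an open substituted amino group does not by itself read better than azetidin-1-yl, with the propargylamino group of compound 3 as the exception; no measurement shown explains the difference between ethynyl and cyclopropyl.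

The compounds shown leave open whether the better reading of propargyl belongs to its triple bond, which an n-propyl or allyl group on the sulfonamide nitrogen would help to separate. Going by these compounds, it also remains open whether a methyl group there would read closer to compound 1 or to compound 4.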